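Trimming the benzyloxy group: what compound 4 might show

A few compounds are considered here, and "the series" means these few. Any claim that something is new, unique, unknown or untested is made for them only; others in the source may bear on it.

Measured so far:
Compound 1 `CN(Cc1cn(CC(O)COC(=O)NCc2ccccc2)nn1)CC1CCCCC1` gives 32% in an assay on nucleic acid for inhibition of Nucleic Acid, read by fluorescence, tested at 100 uM; a higher number here means more inhibition at the concentration tested (going by the name of the read-out), a lower number less inhibition.
Compound 2 `CN(Cc1cn(CC(O)COCc2ccccc2)nn1)CC1CCCCC1` gives 6% in this assay.
Compound 3 `CN(CCCc1ccccc1)Cc1cn(CC(O)COCc2ccccc2)nn1` gives 18% in this assay.

Compound 2 has the lowest number of the three. Its nearest neighbour is compound 3, reached by a step of a number 12 percentage points higher from compound 2 to compound 3 (beyond the scatter), and its furthest is compound 1, since compound 1 sits higher by the amount seen in a number 26 percentage points lower from compound 1 to compound 2 (beyond the scatter) read backwards. Both steps lie beyond the scatter, but both are modest.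

Compound 4 `CCCCC(O)Cn1cc(CN(C)CC2CCCCC2)nn1` differs from compound 2 in one place: propyl in place of benzyloxy on a saturated chain carbon, two bonds along the chain from an oxygen on a saturated carbon. Neither measured step touches this part of the molecule. The step from compound 1 to compound 2 changed what hangs on the oxygen on a saturated carbon, and the step from compound 2 to compound 3 changed a group on the amine side. For the measured compounds named here, no measured pair shows what happens when the benzyloxy group itself is replaced by propyl, so there is nothing to lean on for direction or size.

Compound 2 is already near the floor of the scale, which leaves little room for a fall. The expected step is a number 2 percentage points higher from compound 2 to compound 4 (within the scatter), essentially none beyond the scatter. Compound 4 is therefore estimated at 8%, within -6% to 24%.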

Compound 4, a percentage reported as inhibition, at one concentration (the size of the read-out at that concentration, not a potency): 47%
Compound 4: the middle estimate sits 39 percentage points below what was measured, outside the stated range (above it).
By their numbers in this assay, from the lowest: compound 2; then compound 3; then compound 1; then compound 4.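

At this place, on a saturated chain carbon two bonds along the chain from an oxygen on a saturated carbon, putting propyl in place of benzyloxy gives a number 41 percentage points higher from compound 2 to compound 4 (beyond the scatter) in this assay and is the only step shown that is large. The earlier step at this end of the molecule, a number 26 percentage points lower from compound 1 to compound 2 (beyond the scatter), changed only what sits on the oxygen, whereas this one shows that a high number in this assay does not require the oxygen, the six-membered aromatic ring or a carbamoyl group at this end. Nothing shown explains why the smaller, ring-free group gives the higher number.

This single swap removes the ring and the oxygen and shortens the group all at once, so the compounds shown do not say which of these changes matters; a propoxy group or a phenylpropyl group in the same place could begin to separate them, and a longer chain such as hexyl could show whether the number keeps rising with chain length. Also open, going by these compounds, is whether the change from cyclohexyl to phenethyl on the amine side would raise the number on the propyl compound as well.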